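Trimming a Hydroxyethoxy Chain: Effect on Solubility

The compounds below may be only part of what the source reports. "The series", "measured", "known", "first", "only" and "open" are said of these compounds alone.

The measured compounds:
compound 1, `COc1ccc(C(=O)C2=C(O)C(=O)N(c3ccc(-c4ccon4)cc3)C2c2ccccc2OC)cc1`, with 34700 nM.
compound 2, `COc1ccc(C(=O)C2=C(O)C(=O)N(c3ccc(-c4ccon4)cc3)C2c2ccccc2OCCO)cc1`, where the result is a limit of the assay, > 50000 nM.
compound 3, `CC(C)(C)C(=O)C1=C(O)C(=O)N(c2ccc(-c3ccsc3)cc2)C1c1ccccc1OCCO`, where the result is likewise a limit of the assay, > 50000 nM.

Among the measured compounds shown here, in a physicochemical assay for solubility, in phosphate buffer, at pH 6.8 (a higher number here means a more soluble compound, a lower number a less soluble compound), the one counted step between measured compounds is hydrogen in place of hydroxymethyl on a saturated chain carbon bound to an oxygen on an aromatic ring, which gave an at least 1.4-fold lower number from compound 2 to compound 1 (0.15 log units; that floor lies within the scatter). Compound 2 sits at the limit (the limit of > 50000 nM in this assay, at which 2 of the 3 values shown sit), so the true size of that step is not known. How the cores of compound 2 and compound 3 differ is not broken down here.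

Compound 4, `COc1ccccc1C1C(C(=O)C(C)(C)C)=C(O)C(=O)N1c1ccc(-c2ccsc2)cc1`, differs from compound 3 by hydrogen in place of hydroxymethyl on a saturated chain carbon bound to an oxygen on an aromatic ring. For the measured compounds named here, this is the same change, at the same place, as the one made from compound 2 to compound 1. For compound 4 a step of an at least 1.6-fold lower number from compound 3 to compound 4 (0.22 log units; that floor lies within the scatter) in this assay is expected, resting on the measured step of an at least 1.4-fold lower number from compound 2 to compound 1 (0.15 log units; that floor lies within the scatter), which is itself only a floor. Compound 4 is therefore estimated to give about 30000 nM in this assay, most likely between 10000 nM and 60000 nM.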

Compound 4, solubility: 900 nM
Estimate against measurement, compound 4: 33-fold (1.52 log units) above; measured number below the stated range.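

In this assay, the change from 2-hydroxyethoxy to methoxy on the core of compound 3 gives an at least 55-fold lower number from compound 3 to compound 4 (1.74 log units; beyond the scatter), a large step beyond the scatter. The same change on the core of compound 2 gives an at least 1.4-fold lower number from compound 2 to compound 1 (0.15 log units; that floor lies within the scatter), so the floor read on that core gave no sign of how large the step could be on the other. This does not show that the change acts differently on the two cores, since each step rests on a single pair and both are only floors, with compound 2 and compound 3 each at a limit of the assay: the limit of > 50000 nM in this assay, at which 2 of the 4 values shown sit.

As far as these compounds go, the true values of compound 2 and compound 3 stay open, and with them whether the step on the core of compound 2 is just as large. Also open, from the compounds shown here alone, is how an amine, a carboxylic acid or a longer chain ending in hydroxyl would read in this assay in place of the 2-hydroxyethoxy group.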